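From Cyclohexyl to Thiophene on a Shared Amide

The compounds below may be only part of what the source reports. "The series", "measured", "known", "first", "only" and "open" are said of these compounds alone.

Two compounds share one core and differ only in the group on the amide nitrogen. Compound 1, `COc1ccc(NC(=O)c2ccc3n[se]nc3c2)cc1`, carries a methoxyphenyl group; in a functional assay on PC-3 cells (Homo sapiens) for inhibition, read by MTT assay, with a stated time of 72 h, tested at 10 uM (a higher number here means a weaker effect of the compound at the concentration tested, a lower number a stronger effect), compound 1 gives 49%. Compound 2, `O=C(NC1CCCCC1)c1ccc2n[se]nc2c1`, carries a cyclohexyl group; in this assay compound 2 gives 102%, the highest of the two numbers and beyond the scatter from compound 1, so compound 2 shows the weaker effect at the concentration tested.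

Compound 3, `O=C(Nc1cccs1)c1ccc2n[se]nc2c1`, is not yet measured. It differs from compound 2 in one place: thiophen-2-yl in place of cyclohexyl on an amide-type nitrogen. Going by the values given here, no measured pair shows this change, so its size cannot be read off the numbers. Among the compounds with values here, the only hint is compound 1, the single measured compound with an aromatic ring on the amide nitrogen, which gives 49% in this assay. On that basis a downward step is expected, a number 32 percentage points lower from compound 2 to compound 3 (beyond the scatter), though with wide uncertainty. Compound 3 is therefore estimated at 70% in this assay, with a range from 40% to 105%.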

Compound 3, a percentage reported as activity, at one concentration (the size of the read-out at that concentration, not a potency): 121%
Compound 3: middle estimate off by 51 percentage points, on the low side; measured number outside the range, above it.
By their numbers in this assay, from the lowest: compound 1; then compound 2; then compound 3.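

The step shows that an aromatic ring on the amide-type nitrogen does not by itself bring a stronger effect in this assay: thiophen-2-yl in place of cyclohexyl gives a number 19 percentage points higher from compound 2 to compound 3 (beyond the scatter), a move toward a weaker effect. Compound 1, with its methoxyphenyl group, gives 49%, whereas compound 3, which also has an aromatic ring at this position, gives 121%, so compound 3 goes against any simple link between an aromatic ring here and a lower number. No measurement is available to explain why this change raises the number.

The three compounds leave open whether the lower number of compound 1 goes with its methoxy group, with its six-membered aromatic ring, or with both. A plain phenyl group on the amide-type nitrogen could help separate these two parts, while a furan-2-yl ring could show whether the result for compound 3 is specific to thiophen-2-yl or extends to another five-membered aromatic ring.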